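Methyl to Trifluoromethyl on the Pyrazolyl Group

The compounds below may be only part of what the source reports. "The series", "measured", "known", "first", "only" and "open" are said of these compounds alone.

Compound 2 `CCCC(Oc1ccc(-n2cc(C)cn2)cc1)c1ccc(C(=O)NCCC(=O)O)cc1` carries a 4-methyl-1H-pyrazol-1-yl group on the shared core. Going by the values given here, in a functional assay on cells for antagonist activity at Glucagon receptor (Homo sapiens), read by cAMP accumulation, in the presence of a further agent that is not named here (on this read-out lower numbers stand for stronger inhibition and higher numbers for weaker inhibition), compound 2 gives 11000 nM, the higher of the two numbers known so far. Among the compounds with values here, its only neighbour, compound 1 `CCCC(Oc1ccc(-n2cc3ccccc3n2)cc1)c1ccc(C(=O)NCCC(=O)O)cc1`, gives 2000 nM, and the step of a 5.5-fold higher number from compound 1 to compound 2 (0.74 log units; beyond the scatter) shows that exchanging 2H-indazol-2-yl for 4-methyl-1H-pyrazol-1-yl weakened the antagonist. Compound 3 `CCCC(Oc1ccc(-n2cc(C(F)(F)F)cn2)cc1)c1ccc(C(=O)NCCC(=O)O)cc1` differs from compound 2 by trifluoromethyl in place of methyl on an aromatic carbon. Within the data shown here, no measured pair covers a methyl-to-trifluoromethyl exchange, so the only guidance is the single step from compound 1 to compound 2, which concerned a different part of the same group and does not settle the direction. Compound 3 is therefore expected to land close to compound 2, with a 1.6-fold lower number from compound 2 to compound 3 (0.20 log units; within the scatter) well within a modest change. For compound 3 the estimate in this assay is 7000 nM, ranging from 2000 nM to 20000 nM.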

Compound 3, antagonist equilibrium constant: 5100 nM
Beside the measured number, compound 3's estimate is 1.4-fold (0.14 log units) above it, within the range that was stated.
By their numbers in this assay, from the lowest: compound 1; then compound 3; then compound 2.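

On an aromatic carbon two ring bonds from the ring nitrogen, in this assay, trifluoromethyl in place of methyl gives a 2.2-fold lower number from compound 2 to compound 3 (0.33 log units; beyond the scatter) and so shows that this single position on the pyrazolyl group can shift the number towards stronger inhibition. The 4-(trifluoromethyl)-1H-pyrazol-1-yl group still falls short of the 2H-indazol-2-yl group, with a 2.6-fold higher number from compound 1 to compound 3 (0.41 log units; beyond the scatter) and compound 1 keeping the lowest number of the three. Nothing available explains why the exchange moved the number in this direction.

The compounds shown leave open whether a chlorine atom, a nitrile or an ethyl group on the same carbon would move the number as trifluoromethyl does. They also leave open whether a substituent on the 2H-indazol-2-yl group would lower its number further.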